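Cytotoxicity notes: methyl for bromo on compound 2

A few compounds are considered here, and "the series" means these few. Any claim that something is new, unique, unknown or untested is made for them only; others in the source may bear on it.

Measured compounds in an ADME assay on HEK293 cells (Homo sapiens) for cytotoxicity, read by MTT assay; a lower number here means a stronger inhibitor, a higher number a weaker inhibitor:
- compound 1 `COc1ccc(-n2ncn(Cc3cn(Cc4cc5cc(Cl)ccc5nc4Cl)nn3)c2=O)cc1` gives 1060 ug/mL
- compound 2 `O=c1n(Cc2cn(Cc3cc4cc(Br)ccc4nc3Cl)nn2)cnn1-c1ccccc1` gives 1650 ug/mL
- compound 3 `COc1ccc(-n2ncn(Cc3cn(Cc4cc5cc(Br)ccc5nc4Cl)nn3)c2=O)cc1` gives 333 ug/mL

Compound 2 has the highest number of the three in this assay; its gap to compound 1 is within the scatter, while compound 3 sits well below it, a step of a 5.0-fold lower number from compound 2 to compound 3 (0.70 log units; beyond the scatter).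

Compound 4 `Cc1ccc2nc(Cl)c(Cn3cc(Cn4cnn(-c5ccccc5)c4=O)nn3)cc2c1` is not yet measured. It differs from compound 2 by methyl in place of bromo on an aromatic carbon.

For the measured compounds named here, no measured step exchanges bromo for methyl. The nearest reference is the halogen exchange, where bromo in place of chloro on an aromatic carbon gave a 3.2-fold lower number from compound 1 to compound 3 (0.50 log units; beyond the scatter). That only shows the bromo-bearing member with the lower number; it says nothing direct about methyl. For compound 4 a step in this assay of about the same size is therefore expected, towards a higher number, though a result within the scatter of compound 2 is also plausible.

The expected step is a 1.5-fold higher number from compound 2 to compound 4 (0.16 log units; within the scatter). Compound 4 is estimated at 2400 ug/mL, with a range from 1000 ug/mL to 5500 ug/mL.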

Compound 4, half-maximal inhibitory concentration: 478 ug/mL
Compound 4: middle estimate off by 5.0-fold (0.70 log units), on the high side; measured number outside the range, below it.
By their numbers in this assay, from the lowest: compounds 3 and 4 (each within the scatter of the next); then compounds 1 and 2 (each within the scatter of the next).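

For the compounds shown here, at this position, on the aromatic carbon of the fused system, a non-halogen group is now read for the first time: with methyl in place of bromo, this assay shows a 3.5-fold lower number from compound 2 to compound 4 (0.54 log units; beyond the scatter). Going by these compounds alone, until now, the only change here was the halogen exchange on the methoxy-bearing member, a 3.2-fold lower number from compound 1 to compound 3 (0.50 log units; beyond the scatter), where the bromo compound had the lower number, so a lower number at this position is not tied to bromo; the two steps stand on different members, however, and give no single ranking of chloro, bromo and methyl. Nothing available accounts for the direction of the methyl step.

From the compounds shown here alone, whether methyl in place of bromo gives a step of similar size on the methoxy-bearing member remains open. So does how an amine, a carboxylic acid or a longer chain at this position would read in this assay.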